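The source may report more compounds than this note shows. Statements on the series, on what has been measured and on what is new or still open speak of the compounds shown alone.

Going by the values given here, compound 1 `CC(C)(C)OC(=O)N1CCC(O[C@H]2CC[C@H](Oc3cnc(S(C)(=O)=O)cn3)CC2)CC1` is one of two compounds measured in a functional assay on isolated protein for agonist activity at Glucose-dependent insulinotropic receptor (Rattus norvegicus), read by HTRF and cAMP accumulation; a lower number here means a smaller maximal response, a higher number a larger maximal response; compound 1 gives 110%. Among the compounds with values here, compound 2 `CC(C)(C)OC(=O)N1CCC(O[C@H]2CC[C@H](Oc3cnc(C#N)cn3)CC2)CC1` gives 100% in this assay, and the only measured step, a number 10 percentage points lower from compound 1 to compound 2 (within the scatter), exchanges groups on an aromatic carbon. Compound 1 and compound 2 thus give numbers within the usual scatter of each other, and neither stands apart.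

Compound 3 `C[C@H](CF)OC(=O)N1CCC(O[C@H]2CC[C@H](Oc3cnc(S(C)(=O)=O)cn3)CC2)CC1` differs from compound 1 in another place: 1-(fluoromethyl)ethyl in place of tert-butyl on an oxygen next to a carbonyl group. Within the data shown here, no measured step changes this group on the oxygen next to the carbonyl group, so nothing measured bears directly on it; the one known step, a change on an aromatic carbon, stayed within the scatter. Compound 3 is therefore expected to show a step of a number 5 percentage points lower from compound 1 to compound 3 (within the scatter) in this assay, that is no change beyond the scatter. The estimate for compound 3 is 105%, with a range from 85% to 125%.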

Compound 3, largest response reached (Emax), in percent of the reference or control that the assay uses: 115%
Compound 3: the middle estimate sits 10 percentage points below what was measured, within the range that was stated.
By their numbers in this assay, from the lowest: compounds 2, 1 and 3 (each within the scatter of the next, the first and the last beyond it).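

The group on the oxygen next to a carbonyl group now has a measured step of its own, and in this assay the step of a number 5 percentage points higher from compound 1 to compound 3 (within the scatter) shows that this place accepts 1-(fluoromethyl)ethyl in place of tert-butyl without a change beyond the scatter. The exchange keeps the count of heavy atoms, swaps one carbon for a fluorine and adds a defined stereocentre, and the maximal response still holds through all of that. No measured information explains why the response holds.

On these data alone, it stays open whether a benzyl group or a chain carrying an amine on this oxygen would also stay within the scatter of compound 1. As far as these compounds go, the mirror-image form of the 1-(fluoromethyl)ethyl group also remains open.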